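This account rests on a few compounds, and the source may have more. Where it says the series, first, only, none or still open, it means among the compounds named here.

For the measured compounds named here, compound 2 `CC(C)=CCC[C@]1(C)/C=C/[C@@H](OC(=O)C=C(C)C)[C@](C)(O)/C=C/C(=O)/C(Cn2cc(CO)nn2)=C\C1` stands at the weaker end of the two compounds measured so far in a functional assay on MCF7 cells (Homo sapiens) for antiproliferative activity, read by MTT assay, with a stated time of 48 h; a higher number here means a weaker inhibitor, a lower number a stronger inhibitor: compound 2 gives 2930 nM, whereas compound 1 `CC(C)=CCC[C@]1(C)/C=C/[C@@H](OC(=O)C=C(C)C)[C@](C)(O)/C=C/C(=O)/C(CF)=C\C1` gives 240 nM. Going by the values given here, the only step on record, 4-(hydroxymethyl)-1H-1,2,3-triazol-1-yl in place of fluoro on a saturated chain carbon bound to a double-bonded ring carbon, is a 12-fold higher number from compound 1 to compound 2 (1.09 log units; beyond the scatter). Compound 3 `CO/N=C/C1=C/C[C@](C)(CCC=C(C)C)/C=C/[C@@H](OC(=O)C=C(C)C)[C@](C)(O)/C=C/C1=O` differs from compound 2 at that same double-bonded ring carbon: a group of 4 heavy atoms (2 carbon, 1 nitrogen, 1 oxygen; no ring) in place of a group of 8 heavy atoms (4 carbon, 3 nitrogen, 1 oxygen; one five-membered aromatic ring with 3 hetero atoms), on a double-bonded ring carbon. Among the compounds with values here, no measured step covers the entering group, so the step from compound 1 to compound 2 is the only guide; it shows that adding the triazole-bearing group gave the markedly higher number, and compound 3 removes that group again. Because the step of a 12-fold higher number from compound 1 to compound 2 (1.09 log units; beyond the scatter) was large, a lower number in this assay is expected for compound 3, though the entering group is not fluoro. For compound 3 the expected step of a 3.7-fold lower number from compound 2 to compound 3 (0.56 log units; beyond the scatter) is therefore taken as a partial reversal rather than a full one. The estimate for compound 3 is 800 nM, with a range from 250 nM to 3000 nM.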

Compound 3, half-maximal inhibitory concentration: 2510 nM
Compound 3: middle estimate off by 3.1-fold (0.50 log units), on the low side; low and high end bracket the measured number.
By their numbers in this assay, from the lowest: compound 1; then compounds 3 and 2 (each within the scatter of the next).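

In this assay, exchanging the (4-(hydroxymethyl)-1H-1,2,3-triazol-1-yl)methyl group for the ring-free group of compound 3 gives a 1.2-fold lower number from compound 2 to compound 3 (0.07 log units; within the scatter) so the five-membered aromatic ring is not required for a number in this range at this double-bonded ring carbon. Set against the fluoro-bearing compound, the same ring-free group gives a 10-fold higher number from compound 1 to compound 3 (1.02 log units; beyond the scatter) which means that two quite different groups now stand apart from compound 1 on the same side, and the large step seen earlier is not peculiar to the triazole-bearing group. Nothing on hand says why compound 1 differs from compound 2 and compound 3.

Going by these compounds, what remains open is whether a chloro, hydroxy or simple amine group on the saturated chain carbon would give a number near that of compound 1 or one near those of compound 2 and compound 3. On these data alone, it is also open whether a carboxylic acid or a longer chain in place of the hydroxymethyl on the triazole would shift the number at all in this assay or leave it where compound 2 stands.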